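Benzylsulfanyl in Place of Benzylamino on a Nucleoside Core

The source may report more compounds than this note shows. Statements on the series, on what has been measured and on what is new or still open speak of the compounds shown alone.

Compound 1 `Clc1[nH]ccc2ncnc1-2`: > 9 mg/kg
Compound 2 `CSc1nccc2c1ncn2[C@H]1C[C@H](O)[C@@H](CO)O1`: > 9 mg/kg
Compound 3 `OC[C@H]1OC(n2cnc3c(NCc4ccccc4)nccc32)[C@H](O)[C@@H]1O`: > 9 mg/kg

All three compounds were tested in a functional assay on the whole organism (Pleural cavity) with Rattus norvegicus as the target; a higher number here means that more compound is needed for the effect, a lower number that less compound is needed. In this assay compound 3 gives only a limit, > 9 mg/kg, and not a number. Compound 1 and compound 2 stand no differently, because every value shown sits at the limit of > 9 mg/kg in this assay, at which 3 of the 3 values shown sit. So compound 3 has no fixed place on the numbers, only a boundary.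

Compound 4 `OC[C@H]1OC(n2cnc3c(SCc4ccccc4)nccc32)[C@H](O)[C@@H]1O` differs from compound 3 in one place: benzylsulfanyl in place of benzylamino on an aromatic carbon. Among the measured compounds shown here, no step between two measured compounds exists here, so no size of change can be read from the data. The step expected from this change, a step that the limit leaves unreadable from compound 3 to compound 4, is none beyond the scatter. Compound 4 is therefore estimated at 15 mg/kg, within 5 mg/kg to 60 mg/kg, most likely reported again as a limit.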

Compound 4, dose for half-maximal effect: 9 mg/kg
Beside the measured number, compound 4's estimate is 1.7-fold (0.22 log units) above it; the measured number falls inside the stated range.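

In this assay compound 4 gives a real number, 9 mg/kg, so a value can be read at this position, next to the ring nitrogen, with benzylsulfanyl in place. Compound 3 gives > 9 mg/kg, which is a limit of the assay, so the size of the step from benzylamino to benzylsulfanyl cannot be read. Benzylsulfanyl in place of benzylamino on an aromatic carbon gives a number no higher from compound 3 to compound 4 (the limit leaves the size open). Compound 4 is the only compound shown with a number rather than a limit: the limit of > 9 mg/kg in this assay, at which 3 of the 4 values shown sit.

As far as these compounds go, whether a benzyloxy group or a longer chain such as phenethylsulfanyl at this position would need less compound remains open.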